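Exchanging a carboxy for an amino on the aryl ether

The source may hold more compounds than are shown below. What is called first, only, known or untested is meant among the compounds shown, and "the series" means these compounds.

Compound 1, `O=c1ccn(CCCCCOc2ccccc2)c(=O)[nH]1`, carries the shared core on a five-carbon chain ending in a phenoxy group. In an ADME assay on HEL cells (Homo sapiens) for cytotoxicity (on this read-out lower numbers stand for higher toxicity in this test and higher numbers for lower toxicity in this test), compound 1 reaches only the limit of the test, > 100000 nM. Compound 2, `O=C(O)c1ccc(OCCCCCn2ccc(=O)[nH]c2=O)cc1`, adds a carboxy to that aryl ring. In this assay, within the data shown here, compound 2 is recorded as "not determined" (no result reported), so no number places it; the single value shown is the limit of > 100000 nM in this assay, at which 1 of the 2 values shown sits, and compound 2 stands beside it without a figure of its own. Compound 3, `Nc1ccc(OCCCCCn2ccc(=O)[nH]c2=O)cc1`, is the next member and has not been measured in this assay. Its difference from compound 2 is amino in place of carboxy on an aromatic carbon, in words amino in place of carboxy on an aromatic carbon. Among the measured compounds shown here, no measured step between two compounds exists in this set, so the size of this change can only be expected rather than read off: compound 3 is expected to remain at the low-toxicity end, with no shift beyond the scatter to be anticipated for this exchange. Compound 3 is estimated at 150000 nM, with a range from 50000 nM to 500000 nM, and most likely the assay again returns only a limit.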

Compound 3, half-maximal cytotoxic concentration: > 100000 nM
Compound 3 ended at the assay's limit; the forecaster's own chance of this, stated with the estimate: 85%; the middle value lies beyond the limit too.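

In this assay compound 1 and compound 3 stand only at a limit, so no step can be read between them: the limit of > 100000 nM in this assay, at which 2 of the 3 values shown sit. The compounds shown leave open how far either lies beyond that limit, and whether any group on the aryl ring would give a readable value in this assay at all.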